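Indole for isoquinoline on a tetradecyl amide

The source may hold more compounds than are shown below. What is called first, only, known or untested is meant among the compounds shown, and "the series" means these compounds.

Three amides sharing one core have been run in a functional assay on SiHa cells (Homo sapiens) for cytotoxicity, read by MTT assay, with a stated time of 48 h; a higher number here means a weaker inhibitor, a lower number a stronger inhibitor. Compound 1 `CCCCCCCCCCCCNC(=O)[C@@H](NC(=O)c1nccc2ccccc12)[C@@H](C)O` gives 56600 nM. Compound 2 `CCCCCCCCCCCCNC(=O)[C@@H](NC(=O)c1cc2ccccc2[nH]1)[C@@H](C)O` gives 21300 nM; the change 1H-indol-2-yl in place of isoquinolin-1-yl on a carbonyl carbon made the step of a 2.7-fold lower number from compound 1 to compound 2 (0.42 log units; beyond the scatter). Compound 3 `CCCCCCCCCCCCCCNC(=O)[C@@H](NC(=O)c1nccc2ccccc12)[C@@H](C)O` gives 21600 nM; its core differs from that of compound 1 by ethyl in place of hydrogen on a saturated chain carbon, ten or more bonds along the chain from an amide-type nitrogen, and that change made the step of a 2.6-fold lower number from compound 1 to compound 3 (0.42 log units; beyond the scatter). Compound 2 and compound 3 lie within the scatter of each other.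

Compound 4 `CCCCCCCCCCCCCCNC(=O)[C@@H](NC(=O)c1cc2ccccc2[nH]1)[C@@H](C)O` is not yet measured. It differs from compound 3 by 1H-indol-2-yl in place of isoquinolin-1-yl on a carbonyl carbon, the same change, at the same place, as from compound 1 to compound 2. Going by the values given here, the expected step in this assay is therefore a 2.5-fold lower number from compound 3 to compound 4 (0.41 log units; beyond the scatter), resting on the one earlier instance, a 2.7-fold lower number from compound 1 to compound 2 (0.42 log units; beyond the scatter), applied to compound 3, which gives 21600 nM. Compound 4 is estimated at 8500 nM, with a range from 4000 nM to 20000 nM.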

Compound 4, half-maximal inhibitory concentration: 14200 nM
The estimate for compound 4 lay 1.7-fold (0.22 log units) below the measured number; measured number inside the range.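

The change to 1H-indol-2-yl in place of isoquinolin-1-yl on a carbonyl carbon gives a 1.5-fold lower number from compound 3 to compound 4 (0.18 log units; within the scatter) in this assay, and its size does not differ measurably between the two cores: the same change on two cores in this assay, a 2.7-fold lower number (0.42 log units; beyond the scatter) from compound 1 to compound 2 and a 1.5-fold lower number (0.18 log units; within the scatter) from compound 3 to compound 4, 1.7-fold (0.24 log units) apart, within the scatter of two such steps

Ethyl in place of hydrogen on the chain gives a 1.5-fold lower number from compound 2 to compound 4 (0.18 log units; within the scatter), and this change also shows no measurable difference between cores: the same change on two cores in this assay, a 2.6-fold lower number (0.42 log units; beyond the scatter) from compound 1 to compound 3 and a 1.5-fold lower number (0.18 log units; within the scatter) from compound 2 to compound 4, 1.7-fold (0.24 log units) apart, within the scatter of two such steps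

Both changes are thus compatible with carrying over, but each rests on a single pair of steps and its newer step lies within the scatter, so neither is shown to be a fixed increment on further cores.

Still open, from the compounds shown here alone, is how a chain longer than tetradecyl would read out. Also open, going by these compounds, is how an amine or a carboxylic acid would compare with these aromatic groups on the carbonyl carbon.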